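Anilide variation at the amide nitrogen: compound 4

The compounds below may be only part of what the source reports. "The series", "measured", "known", "first", "only" and "open" are said of these compounds alone.

Measured so far in a functional assay on KB cells (Homo sapiens) for inhibition; on this read-out higher numbers stand for weaker inhibition of growth and lower numbers for stronger inhibition of growth:
compound 1 `O=C(COc1ccc(/C=C2\SC(=O)NC2=O)cc1)Nc1ccccc1` — compound 1 gives > 100000 nM, a limit of the assay.
compound 2 `O=C(COc1ccc(/C=C2\SC(=O)NC2=O)cc1)Nc1ccc(Br)cc1` — compound 2 gives 32100 nM.
compound 3 `O=C(COc1ccc(/C=C2\SC(=O)NC2=O)cc1)Nc1ccc(C(F)(F)F)cc1Cl` — compound 3 gives 78600 nM.

Compound 2 holds the lowest of the two numbers shown in this assay; compound 3 sits nearest, beyond the scatter above it. Among the measured compounds shown here, the only one-place step measured is an at least 3.1-fold lower number from compound 1 to compound 2 (0.49 log units; beyond the scatter). That step rests on a bound, since the value for compound 1 is a limit (the limit of > 100000 nM in this assay, at which 1 of the 3 values shown sits).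

Compound 4 `O=C(COc1ccc(/C=C2\SC(=O)NC2=O)cc1)Nc1c(Cl)cccc1Cl` differs from compound 2 by 2,6-dichlorophenyl in place of 4-bromophenyl on an amide-type nitrogen. For the measured compounds named here, no measured step removes bromo or brings in two chloro groups, so the change is not directly covered. Compound 3, carrying chloro and trifluoromethyl, shows a higher number than compound 2. For compound 4 a modest rise in number is expected, a 1.9-fold higher number from compound 2 to compound 4 (0.27 log units; within the scatter). The estimate for compound 4 is 60000 nM, range 20000 nM to 150000 nM.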

Compound 4, concentration for 50% growth inhibition: > 100000 nM
Compound 4 gave a limit, no number; the forecaster's own chance of this, stated with the estimate: 30%; middle value at least 1.6-fold (0.22 log units) away from the limit.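

In this assay, 2,6-dichlorophenyl in place of 4-bromophenyl on the amide-type nitrogen gives an at least 3.1-fold higher number from compound 2 to compound 4 (0.49 log units; beyond the scatter), so the lower number of compound 2 does not extend to this second halogen-bearing anilide. Compound 4 gives > 100000 nM, which is a limit. The step from compound 1 to compound 4 cannot be read, as both compounds rest on the same limit: the limit of > 100000 nM in this assay, at which 2 of the 4 values shown sit.

On these data alone, the full size of the rise to compound 4 stays open. Also open, as far as these compounds go, is whether a single chloro, an amine or a carboxylic acid in place of the bromo would keep the number of compound 2.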